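A few compounds are considered here, and "the series" means these few. Any claim that something is new, unique, unknown or untested is made for them only; others in the source may bear on it.

Measured so far:
compound 1 `Clc1cccc2c1CC2CN1CCN(c2cccc3c2OCCO3)CC1`: 0.63 mg/kg
compound 2 `c1ccc2c(c1)CC(CN1CCN(c3cccc4c3OCCO4)CC1)C2`: 0.63 mg/kg
compound 3 `C1=C(CCN2CCN(c3cccc4c3OCCO4)CC2)c2ccccc2CCC1`: 2.5 mg/kg

In a functional assay on the whole organism for antagonist activity, with Rattus norvegicus as the target (on this read-out higher numbers stand for an effect only at larger amounts of compound and lower numbers for an effect already at smaller amounts), compound 1 gives 0.63 mg/kg, level with compound 2 at the digits shown and together the lowest of the three numbers; the two values lie within the scatter of each other. Compound 3 gives 2.5 mg/kg, a higher number than compound 1 and beyond the scatter. Within the data shown here, no pair of measured compounds differs in a single place, so no measured single step is available.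

Compound 4 `Fc1cccc2c1CC2CN1CCN(c2cccc3c2OCCO3)CC1` differs from compound 1 in one place: fluoro in place of chloro on an aromatic carbon. Compound 2, carrying neither halogen, gives 0.63 mg/kg within the scatter of compound 1, so the substituent at this place has not shifted the read-out so far. For compound 4 the step of no change at the digits printed from compound 1 to compound 4 (within the scatter) is expected to be none beyond the scatter in this assay. Compound 4 is estimated at 0.63 mg/kg, with a range from 0.3 mg/kg to 1.6 mg/kg.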

Compound 4, minimum effective dose: 0.63 mg/kg
Beside the measured number, compound 4's estimate shows no gap at the digits printed, within the range that was stated.
By their numbers in this assay, from the lowest: compounds 1, 2 and 4 (each within the scatter of the next); then compound 3.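

In this assay, among these compounds, the exchange of chloro for fluoro on this aromatic carbon gives no change at the digits printed from compound 1 to compound 4 (within the scatter) and so provides the first single-place step. At this position the read-out therefore does not separate these two halogens. No supporting data offer an account of this result. From the compounds shown here alone, whether methoxy, an amine or a carboxylic acid at this aromatic carbon would leave the read-out equally unmoved remains open. Also open, going by these compounds, is whether fluoro in place of chloro would give a similar step on a different core.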